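The source may report more compounds than this note shows. Statements on the series, on what has been measured and on what is new or still open speak of the compounds shown alone.

Of the compounds shown here, three have been measured in a functional assay on K562 cells (Homo sapiens), read by MTT assay, with a stated time of 72 h; a higher number here means a weaker inhibitor, a lower number a stronger inhibitor.

Compound 1 `COc1nc(N)nc2c1c(-c1cc3ccccc3o1)cn2[C@@H]1O[C@H](CO)[C@@H](O)[C@H]1O` gives 15500 nM.
Compound 2 `C#Cc1cn([C@@H]2O[C@H](CO)[C@@H](O)[C@H]2O)c2ncnc(OC)c12` gives 380 nM.
Compound 3 `C#Cc1cn([C@@H]2O[C@H](CO)[C@@H](O)[C@H]2O)c2nc(N)nc(OC)c12` is reported only as a limit of the assay, > 20000 nM.

Compound 3 thus has no exact number, only (the limit of > 20000 nM in this assay, at which 1 of the 3 values shown sits). Against compound 2 it stands far off, as the step of an at least 52-fold higher number from compound 2 to compound 3 (1.72 log units; beyond the scatter) shows, where amino replaced hydrogen on an aromatic carbon. Against compound 1 the step of an at least 1.2-fold higher number from compound 1 to compound 3 (0.11 log units; that floor lies within the scatter) has a floor that lies within the scatter, so those two cannot be told apart on these numbers.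

Compound 4 `COc1nc(N)nc2c1c(-c1cccs1)cn2[C@@H]1O[C@H](CO)[C@@H](O)[C@H]1O` keeps the amino group and the rest of the core of compound 3 and differs in one place: thiophen-2-yl in place of ethynyl on an aromatic carbon. The step from compound 1 to compound 3 is the only measured one that bears on this, since there 1-benzofuran-2-yl, another five-membered aromatic ring, stood on that aromatic carbon instead of ethynyl, and it was not separable from the scatter. Compound 4 is therefore expected to land near compound 1 and compound 3, with an at least 1.3-fold lower number from compound 3 to compound 4 (0.12 log units; that floor lies within the scatter) expected to be no larger than the scatter, toward a lower number if anything. The estimate for compound 4 is 15000 nM, between 4000 nM and 40000 nM, with a fair chance that only a limit is reported again.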

Compound 4, half-maximal inhibitory concentration: > 20000 nM
Compound 4 was reported as a limit; the forecaster's own chance of this, stated with the estimate: 40%; middle value at least 1.3-fold (0.12 log units) from the limit.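

With thiophen-2-yl on this aromatic carbon, compound 4 joins compound 3 as a second amino-bearing compound in this assay that returns only a limit, not a number: the limit of > 20000 nM in this assay, at which 2 of the 4 values shown sit.

The change from ethynyl to thiophen-2-yl cannot be read, as both ends of that step are limits, so this exchange shows no measurable effect in either direction. Thiophen-2-yl in place of 1-benzofuran-2-yl gives an at least 1.2-fold higher number from compound 1 to compound 4 (0.11 log units; that floor lies within the scatter), so these two groups cannot be told apart either, and with the amino group present, none of the three groups on this carbon stands clearly apart from the others.

Still open, on these data alone, is how thiophen-2-yl or 1-benzofuran-2-yl would read with hydrogen in place of the amino group, the change that gave an at least 52-fold higher number from compound 2 to compound 3 (1.72 log units; beyond the scatter) in the ethynyl pair. Also open, as far as these compounds go, is whether a different group on this aromatic carbon, such as a carboxylic acid or a longer chain like propyl, would bring an amino-bearing compound back to a measurable number.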